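Pyridinyl for Hydroxymethyl on a Fused Core

This account rests on a few compounds, and the source may have more. Where it says the series, first, only, none or still open, it means among the compounds named here.

Of the compounds shown here, three have been measured in a functional assay on CAL1 cells for inhibition of chemerin-like receptor 1 (Homo sapiens), with a stated time of 45 min; on this read-out lower numbers stand for stronger inhibition and higher numbers for weaker inhibition. Compound 1 `C[C@H](c1ccc(-c2cc(Cl)ccc2-c2nc(=O)o[nH]2)cc1)N(CC1CC1)c1nc2c(C(=O)O)cccc2o1` gives 1.3 nM, compound 2 `CCCCN(c1nc2c(NS(C)(=O)=O)cccc2o1)[C@H](C)c1ccc(-c2ccccc2-c2nnn[nH]2)cc1` gives 14 nM, and compound 3 `CCCCN(c1nc2c(CO)cccc2o1)[C@H](C)c1ccc(-c2ccccc2-c2nnn[nH]2)cc1` gives 24 nM. Compound 3 thus stands with the highest number of the three; its nearest neighbour is compound 2, as seen in the step of a 1.7-fold higher number from compound 2 to compound 3 (0.23 log units; within the scatter), while the gap to compound 1, whose structure differs in several places, lies beyond the scatter.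

Compound 4 `CCCCN(c1nc2c(-c3ccccn3)cccc2o1)[C@H](C)c1ccc(-c2ccccc2-c2nnn[nH]2)cc1` has not yet been measured in this assay. It differs from compound 3 in one place: pyridin-2-yl in place of hydroxymethyl on an aromatic carbon. Within the data shown here, of the measured steps, only the one from compound 2 to compound 3 touches the same aromatic carbon, and that step was within the scatter; it exchanged one group for another, whereas the change to compound 4 brings in a six-membered aromatic ring, for which no measured step exists. The expectation for compound 4 is therefore a step of about a 1.3-fold higher number from compound 3 to compound 4 (0.10 log units; within the scatter) in this assay, of uncertain direction and not clearly beyond the scatter. Compound 4 is estimated at 30 nM, with a range from 8 nM to 120 nM.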

Compound 4, half-maximal inhibitory concentration: 110 nM
Compound 4: middle estimate off by 3.7-fold (0.56 log units), on the low side; low and high end bracket the measured number.
By their numbers in this assay, from the lowest: compound 1; then compounds 2 and 3 (each within the scatter of the next); then compound 4.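

In this assay, among these compounds, exchanging hydroxymethyl for pyridin-2-yl on this aromatic carbon gives a 4.6-fold higher number from compound 3 to compound 4 (0.66 log units; beyond the scatter) and is the first change here to move the number beyond the scatter at this position, while exchanging methanesulfonamido for pyridin-2-yl gives a 7.9-fold higher number from compound 2 to compound 4 (0.90 log units; beyond the scatter) in the same direction. The earlier step, a 1.7-fold higher number from compound 2 to compound 3 (0.23 log units; within the scatter) between two groups of quite different make-up, could have suggested that this carbon tolerates whatever it carries, but among the three groups now compared that no longer holds, as the one bringing in a six-membered aromatic ring stands apart from the other two. Nothing at hand bears on why the number rises with this exchange.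

The compounds shown leave open whether the rise belongs to aromatic rings at this carbon in general or to pyridin-2-yl in particular, a question that phenyl, pyridin-3-yl or a saturated ring such as piperidinyl on the otherwise unchanged structure of compound 3 would address. They also leave open how a small group such as an amine or a methoxy group would fare at the same carbon.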